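Propyl to tert-butyl: expected step for compound 4

The source may hold more compounds than are shown below. What is called first, only, known or untested is meant among the compounds shown, and "the series" means these compounds.

Measured so far in an ADME assay on the whole organism with Oryza sativa as the target, tested at 10 uM; a higher number here means a weaker effect of the compound at the concentration tested, a lower number a stronger effect:
compound 1 `CCc1ccc(NC(=O)N[C@H](C)c2ccccc2)cc1` gives 44%;
compound 2 `CC(C)c1ccc(NC(=O)N[C@H](C)c2ccccc2)cc1` gives 49%;
compound 3 `CCCc1ccc(NC(=O)N[C@H](C)c2ccccc2)cc1` gives 35%.

Compound 3 holds the lowest of the three numbers; its nearest neighbour is compound 1, with a number 9 percentage points lower from compound 1 to compound 3 (within the scatter), and its furthest is compound 2, with a number 14 percentage points lower from compound 2 to compound 3 (beyond the scatter). For the measured compounds named here, the only step beyond the scatter in this small set is thus the one between compound 2 and compound 3.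

Compound 4 `C[C@@H](NC(=O)Nc1ccc(C(C)(C)C)cc1)c1ccccc1` is not yet measured. It differs from compound 3 by tert-butyl in place of propyl on an aromatic carbon. The step that bears most on this change is a number 14 percentage points lower from compound 2 to compound 3 (beyond the scatter), the exchange of one four-carbon-free branched arrangement for a straight chain on the same aromatic carbon. The step of a number 5 percentage points higher from compound 1 to compound 2 (within the scatter) adds a methyl at the same branch point and stays within the scatter. Taken together, a modest rise in this assay is expected for compound 4, roughly reversing the step from compound 2 to compound 3, which means an estimated a number 13 percentage points higher from compound 3 to compound 4 (beyond the scatter). Compound 4 is therefore expected to give about 48%, with a range from 34% to 62%.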

Compound 4, a percentage reported as activity, at one concentration (the size of the read-out at that concentration, not a potency): 53%
The estimate for compound 4 lay 5 percentage points below the measured number; low and high end bracket the measured number.
By their numbers in this assay, from the lowest: compounds 3, 1, 2 and 4 (each within the scatter of the next, the first and the last beyond it).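

In this assay, tert-butyl in place of propyl on this aromatic carbon gives a number 18 percentage points higher from compound 3 to compound 4 (beyond the scatter), so propyl now stands apart from two branched groups rather than one. Tert-butyl itself cannot be separated from isopropyl or ethyl, with a number 4 percentage points higher from compound 2 to compound 4 (within the scatter) and a number 9 percentage points higher from compound 1 to compound 4 (within the scatter), and compound 3 remains within the scatter of compound 1, so the only separations in the set are those of propyl from the two branched groups. Adding a methyl to the ethyl and isopropyl groups gives steps that cannot be told apart: the same change on two cores in this assay, a number 9 percentage points lower (within the scatter) from compound 1 to compound 3 and a number 4 percentage points higher (within the scatter) from compound 2 to compound 4, 13 percentage points apart, within the scatter of two such steps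

As far as these compounds go, whether the separation belongs to straight chains generally stays open, as it rests on propyl alone and ethyl does not share it. A longer chain such as butyl, or an amine or a carboxylic acid on this aromatic carbon, could still fall on either side.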